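The compounds below may be only part of what the source reports. "The series", "measured", "known", "first", "only" and "open" are said of these compounds alone.

Values in an ADME assay on HepG2 2.2.15 cells (Homo sapiens) for cytotoxicity, read by CCK-8 assay, with a stated time of 8 days; on this read-out higher numbers stand for lower toxicity in this test and lower numbers for higher toxicity in this test:

Compound 1 `COc1ccc(-c2cc(NC(=O)c3ccc(Cl)cc3O)c[nH]c2=O)cc1`: 50500 nM
Compound 2 `Cc1cccc(-c2cc(NC(=O)c3ccccc3O)c[nH]c2=O)c1`: 98800 nM
Compound 3 `COc1ccc(C(=O)Nc2c[nH]c(=O)c(-c3cccc(C)c3)c2)c(O)c1`: > 100000 nM (a limit)

Compound 3 has no exact number on this read-out. Its entry of > 100000 nM is a limit of the assay, which places it at the limit of > 100000 nM in this assay, at which 1 of the 3 values shown sits.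

Compound 4 `Cc1cccc(-c2cc(NC(=O)c3ccc(Cl)cc3O)c[nH]c2=O)c1` differs from compound 3 by chloro in place of methoxy on an aromatic carbon.

Among the measured compounds shown here, the one measured step at this place, an at least 1.0-fold higher number from compound 2 to compound 3 (0.00 log units; that floor lies within the scatter), puts methoxy in place of hydrogen and stays within the scatter. Compound 4 carries the same chloro group as compound 1. Compound 1 gives 50500 nM, while compound 2 gives 98800 nM. These two values lie within the scatter of each other, so they offer only weak guidance.

Resting on the value of compound 1, a modest shift toward lower numbers in this assay is expected, an estimated at least 1.5-fold lower number from compound 3 to compound 4 (0.18 log units; that floor lies within the scatter). In this assay the estimate for compound 4 is 65000 nM, with an expected range of 30000 nM to 100000 nM.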

Compound 4, half-maximal cytotoxic concentration: 33100 nM
The estimate for compound 4 lay 2.0-fold (0.29 log units) above the measured number; the measured number falls inside the stated range.
By their numbers in this assay, from the lowest: compounds 4, 1 and 2 (each within the scatter of the next, the first and the last beyond it). At a limit, above all of these: compound 3.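

In this assay, a change at this position, meta to a hydroxy group and para to a large group, now moves the number beyond the scatter, which the methoxy step did not do: chloro in place of hydrogen gives a 3.0-fold lower number from compound 2 to compound 4 (0.47 log units; beyond the scatter), and chloro in place of methoxy gives an at least 3.0-fold lower number from compound 3 to compound 4 (0.48 log units; beyond the scatter). The second of these steps is only a floor, since compound 3 stands at a limit of the assay: the limit of > 100000 nM in this assay, at which 1 of the 4 values shown sits. With chloro held fixed, 3-methylphenyl in place of 4-methoxyphenyl gives a 1.5-fold lower number from compound 1 to compound 4 (0.18 log units; within the scatter), which lies within the scatter.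

On these data alone, the effect of chloro is thus read only alongside 3-methylphenyl, and whether it holds alongside 4-methoxyphenyl stays open. As far as these compounds go, whether fluoro, bromo or an amine at this position would lower the number as chloro does also remains unknown.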